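Para-chloro on the phenyl of a bromophenol triazole

A few compounds are considered here, and "the series" means these few. Any claim that something is new, unique, unknown or untested is made for them only; others in the source may bear on it.

Measured so far:
- compound 1 `C=C1C[C@]23C[C@@]1(O)CC[C@H]2c1ccc(O)c(C)c1[C@@H]3Cn1cc(-c2ccccc2)nn1` gives > 20000 nM in a functional assay on HL-60 cells (Homo sapiens) for cytotoxicity, read by MTT assay, with a stated time of 4 days; on this read-out lower numbers stand for stronger inhibition and higher numbers for weaker inhibition
- compound 2 `C=C1C[C@]23C[C@@]1(O)CC[C@H]2c1cc(Br)c(O)c(C)c1[C@@H]3Cn1cc(-c2ccccc2)nn1` gives > 20000 nM in this assay
- compound 3 `C=C1C(=O)[C@]23C[C@@]1(O)CC[C@H]2c1ccc(O)c(C)c1[C@@H]3Cn1cc(-c2ccc(OC)cc2)nn1` gives 1150 nM in this assay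

In this assay compound 2 sits at a limit of the assay, with > 20000 nM reported rather than a number. Compound 1 likewise sits at a limit, with > 20000 nM. Among the compounds with values here, compound 3 is the only measured compound with a number, 1150 nM, and it differs from compound 1 in two places, so no single step can be read between them.

Compound 4 `C=C1C[C@]23C[C@@]1(O)CC[C@H]2c1cc(Br)c(O)c(C)c1[C@@H]3Cn1cc(-c2ccc(Cl)cc2)nn1` is the next compound, not yet measured. It differs from compound 2 by chloro in place of hydrogen on an aromatic carbon. Within the data shown here, the only measured single step is a step that the two limits leave unreadable from compound 1 to compound 2, which cannot be sized because both of its ends are limits, as the limit of > 20000 nM in this assay, at which 2 of the 3 values shown sit, shows. Among the measured compounds shown here, no measured step concerns a change on the phenyl group itself.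

With two of three values at a limit and no readable step, the expectation for compound 4 is that the change leaves the read-out close to where compound 2 stands, and the step that the limit leaves unreadable from compound 2 to compound 4 is expected to be small, in no firm direction. Compound 4 is estimated at 25000 nM, within 6000 nM to 100000 nM, with a limit the most likely report.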

Compound 4, half-maximal inhibitory concentration: 5590 nM
Compound 4: the middle estimate sits 4.5-fold (0.65 log units) above what was measured; measured number below the stated range.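

In this assay, within the data shown here, the change from phenyl to 4-chlorophenyl gives an at least 3.5-fold lower number from compound 2 to compound 4 (0.55 log units; beyond the scatter), the first single change in this set whose size can be read at all. It shows that the phenyl group is not a silent part of these molecules: one chlorine atom, placed on an aromatic carbon para to a large group, is enough to bring a compound from the limit of the assay to a real number. Compound 2 gives > 20000 nM, which is a limit and not a number, so the printed size of the step is only a floor and the true step could be larger: the limit of > 20000 nM in this assay, at which 2 of the 4 values shown sit.

The compounds shown leave open whether this drop belongs to chloro in particular or whether another group at the same place, such as fluoro, trifluoromethyl or an amine, would move the number as far or further. Among these compounds, they also leave open whether chloro would have the same effect without the bromo, on the core of compound 1, where no pair of compounds isolates that change.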